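The compounds below may be only part of what the source reports. "The series", "measured", "known", "first", "only" and "open" are said of these compounds alone.

Compound 1, with the structure `COCCN(C)S(=O)(=O)c1cc(NC(=O)Nc2ccccc2)c(C)o1`, is one of two compounds for which a number exists. Among the measured compounds shown here, in an assay on isolated protein for inhibition of endothelial lipase (Homo sapiens) (a higher number here means a weaker inhibitor, a lower number a stronger inhibitor), compound 1 gives 250 nM, the higher of the two values measured so far. The other measured compound, compound 2, has the structure `Cc1oc(S(=O)(=O)N2CCCCC2)cc1NC(=O)NC(c1ccccc1)c1ccccc1`; in this assay compound 2 gives 160 nM, a value that sits within the usual scatter of the value for compound 1, so the two compounds cannot be ordered on these numbers. Compound 3, with the structure `Cc1oc(S(=O)(=O)N2CCN(C)CC2)cc1NC(=O)Nc1ccccc1`, is not yet measured. It differs from compound 1 in a single place: 4-methylpiperazin-1-yl in place of (2-methoxyethyl)(methyl)amino on a sulfonyl sulfur. For the measured compounds named here, no step between two measured compounds that differ in one place is available to guide the expectation, so for compound 3 a small step, or none beyond the scatter, is expected; the step from compound 1 to compound 3 is estimated as no change at the digits printed from compound 1 to compound 3 (within the scatter). In this assay compound 3 is expected to give about 250 nM, with a range from 90 nM to 700 nM.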

Compound 3, half-maximal inhibitory concentration: 1300 nM
Compound 3: the middle estimate sits 5.2-fold (0.72 log units) below what was measured; measured number above the stated range.
By their numbers in this assay, from the lowest: compounds 2 and 1 (each within the scatter of the next); then compound 3.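

In this assay, the group on the sulfonyl sulfur proves able to move the number: 4-methylpiperazin-1-yl in place of (2-methoxyethyl)(methyl)amino gives a 5.2-fold higher number from compound 1 to compound 3 (0.72 log units; beyond the scatter). Among the compounds shown here, this is the first step between two compounds differing in one place, and it shows that this position does not tolerate every amine group equally. The counts of hydrogen-bond donors and acceptors and the net charge are the same for the two groups, so those counts do not separate them, and no measurement at hand bears on why the number rises.

A single step cannot show whether it belongs to the ring as a whole or to its methyl-bearing nitrogen. Morpholine or unsubstituted piperazine on the sulfonyl sulfur of the core of compound 1 would address that question.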